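Dropping the Methyl from the Thioamide Chain

The source may hold more compounds than are shown below. What is called first, only, known or untested is meant among the compounds shown, and "the series" means these compounds.

In a functional assay on the whole organism (stomach) for inhibition, with Rattus norvegicus as the target, at a dose of 100 mg/kg by the intraduodenal route (on this read-out higher numbers stand for more inhibition at the one dose given (going by the name of the read-out) and lower numbers for less inhibition), compound 1 `N=C(S)CCN1N=C(c2cccs2)CCC1=O` gives 58.5%, while compound 2 `CC(CN1N=C(c2ccccc2)CCC1=O)C(=N)S` gives 28.2%, the lowest of the two numbers and a gap beyond the usual scatter. Compound 3 `N=C(S)CCN1N=C(c2ccccc2)CCC1=O` has not yet been measured in this assay. The change from compound 2 to compound 3 is hydrogen in place of methyl on a saturated chain carbon bound to a carbon with a double bond to nitrogen and a saturated chain carbon. Going by the values given here, no single-change step between measured compounds exists to set the size. Compound 1 also carries this chain without the methyl and gives 58.5%. Guided by that, the step of a number 16.8 percentage points higher from compound 2 to compound 3 (beyond the scatter) is expected to run upward. Compound 3 is expected to give 45%, within a range from 25% to 65%.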

Compound 3, a percentage reported as inhibition, in the whole organism at one dose (the size of the read-out at that dose, not a potency): 38.2%
Compound 3: middle estimate off by 6.8 percentage points, on the high side; the range from low to high includes it.
By their numbers in this assay, from the lowest: compounds 2 and 3 (each within the scatter of the next); then compound 1.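

In this assay, hydrogen in place of methyl on this saturated chain carbon gives a number 10 percentage points higher from compound 2 to compound 3 (within the scatter), so this pair shows no clear effect of the methyl. The larger difference lies elsewhere: phenyl in place of thiophen-2-yl on the carbon with a double bond to nitrogen gives a number 20.3 percentage points lower from compound 1 to compound 3 (beyond the scatter). Nothing measured here explains either step.

Still open, from the compounds shown here alone, is whether an ethyl group on the same chain carbon would behave like the methyl. Going by these compounds, it is also open whether a furan-2-yl ring in place of phenyl would track the thiophen-2-yl compound.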